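Benzyloxy for methoxy on the acetanilide of compound 3

The source may report more compounds than this note shows. Statements on the series, on what has been measured and on what is new or still open speak of the compounds shown alone.

Measured so far:
compound 1 `C#CCN(C)C(=O)c1nc2ccccc2n1Cc1ccc(OC)cc1` — > 10000 nM
compound 2 `C#CCN(C)C(=O)c1cc2cc(C)ccc2n1Cc1ccc(OC)nc1` — 983 nM
compound 3 `COc1ccc(CN(C(C)=O)c2cc(C)cc(C)c2)cc1` — 2790 nM

In an assay on HEK293 cells for displacement of a labelled ligand from Translocator protein (Homo sapiens), read by scintillation counting, with a stated time of 90 min (on this read-out lower numbers stand for stronger inhibition and higher numbers for weaker inhibition), compound 1 returns only a limit of the assay, > 10000 nM (the limit of > 10000 nM in this assay, at which 1 of the 3 values shown sits). Compound 2 gives 983 nM. Compound 3 gives 2790 nM, the higher of the two numbers; compound 2 sits one step beyond the scatter lower. Compound 4 `CC(=O)N(Cc1ccc(OCc2ccccc2)cc1)c1cc(C)cc(C)c1` keeps everything of compound 3 except (phenyl in place of hydrogen on a saturated chain carbon bound to an oxygen on an aromatic ring). Among the compounds with values here, no measured pair in this set carries this change, so its size is open. Taking it as a modest gain in binding, the step from compound 3 to compound 4 is expected to be a 1.9-fold lower number from compound 3 to compound 4 (0.27 log units; within the scatter). Compound 4 is estimated at 1500 nM, within 400 nM to 6000 nM.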

Compound 4, inhibition constant: 738 nM
Compound 4: the middle estimate sits 2.0-fold (0.31 log units) above what was measured, and the stated range covers the measured number.
By their numbers in this assay, from the lowest: compounds 4 and 2 (each within the scatter of the next); then compound 3. At a limit, above all of these: compound 1.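

In this assay, within the data shown here, methoxy to benzyloxy on the acetanilide gives a 3.8-fold lower number from compound 3 to compound 4 (0.58 log units; beyond the scatter) and is the only single-place step so far. A saturated chain carbon bound to an oxygen on an aromatic ring therefore accepts a phenyl in place of hydrogen, with stronger inhibition rather than a loss. Nothing measured here accounts for the size of this step. Open, as far as these compounds go, is whether the aromatic ring itself matters, which a cyclohexyl or a plain propyl chain at this carbon would address. Also open, from the compounds shown here alone, is how a carboxylic acid or an amine on the added phenyl would read.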